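This account rests on a few compounds, and the source may have more. Where it says the series, first, only, none or still open, it means among the compounds named here.

In an ADME assay on Vero cells (Chlorocebus sabaeus) for cytotoxicity, read by MTT assay, with a stated time of 72 h (on this read-out higher numbers stand for lower toxicity in this test and lower numbers for higher toxicity in this test), compound 1 `COc1cccc(-c2cc(-c3ccc(C4NC(=O)c5ccccc5N4)cc3)nc(N)n2)c1OC` gives > 400000 nM, which is a limit of the assay and not an exact number. Compound 3 `CC1(c2ccc(NC(c3ccc(Br)cc3)c3nnnn3C3CCCCC3)cc2)NC(=O)c2ccccc2N1` gives > 400000 nM, which is also a limit. Compound 2 `CC(C)(C)Nc1nc(Nc2ccc(C3(C)NC(=O)c4ccccc4N3)cc2)nc(NC(C)(C)C)n1` is the only one of the three with an exact number, at 159000 nM. Compound 1 therefore stands at the limit of > 400000 nM in this assay, at which 2 of the 3 values shown sit, with no exact value to start from.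

Compound 4 `Nc1nc(-c2ccc(Br)cc2)cc(-c2ccc(C3NC(=O)c4ccccc4N3)cc2)n1` has not yet been measured. It keeps the core of compound 1 but differs at one place: 4-bromophenyl in place of 2,3-dimethoxyphenyl on an aromatic carbon. In words, this is 4-bromophenyl in place of 2,3-dimethoxyphenyl on an aromatic carbon.

Going by the values given here, no two measured compounds differ in just one place, so no measured step can serve as a guide, and the expectation is only a rough one. A small move toward lower numbers, meaning somewhat higher toxicity in this test, is expected, and the estimated size is an at least 1.6-fold lower number from compound 1 to compound 4 (0.20 log units; that floor lies within the scatter). The result could also simply be the same limit again. The estimated value for compound 4 is 250000 nM, with an expected range from 90000 nM to 400000 nM.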

Compound 4, half-maximal cytotoxic concentration: > 400000 nM
Compound 4: only a limit was reported; the forecaster's own chance of this, stated with the estimate: 45%; at least 1.6-fold (0.20 log units) between middle value and limit.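

In this assay, going by these compounds alone, compound 1 and compound 4 each give only a limit and not an exact number, so no step between them can be read. The compounds shown leave open whether 4-bromophenyl in place of 2,3-dimethoxyphenyl changes toxicity in this test at all. Most results sit at one ceiling: the limit of > 400000 nM in this assay, at which 3 of the 4 values shown sit.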